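The compounds below may be only part of what the source reports. "The series", "measured", "known", "first", "only" and "open" are said of these compounds alone.

For the measured compounds named here, compound 1 `Cc1cccc(C2(CNC(=O)Nc3c(C(C)C)cccc3C(C)C)CCCC2)c1` is the stronger of the two compounds measured so far: in an assay on microsomes for inhibition of acyl-CoA:cholesterol acyltransferase (Oryctolagus cuniculus) (on this read-out lower numbers stand for stronger inhibition and higher numbers for weaker inhibition), compound 1 gives 15 nM, while compound 2 `CC(C)c1cccc(C(C)C)c1NC(=O)NCC1(c2ccc(C(F)(F)F)cc2)CCCC1` gives 66 nM, a change of a 4.4-fold higher number from compound 1 to compound 2 (0.64 log units; beyond the scatter). Compound 3 `CC(C)c1cccc(C(C)C)c1NC(=O)NCC1(c2cccc(N)c2)CCCC1` differs from compound 1 by amino in place of methyl on an aromatic carbon. Going by the values given here, the one measured step changed the same ring but with a different group at a different place, so it only loosely bears here; it suggests that altering this ring costs some potency. A step of a 2.7-fold higher number from compound 1 to compound 3 (0.43 log units; beyond the scatter) is therefore expected, and compound 3 is estimated at 40 nM, between 12 nM and 130 nM.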

Compound 3, half-maximal inhibitory concentration: 21 nM
The estimate for compound 3 lay 1.9-fold (0.28 log units) above the measured number; measured number inside the range.
By their numbers in this assay, from the lowest: compounds 1 and 3 (each within the scatter of the next); then compound 2.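

In this assay, 3-aminophenyl in place of 3-methylphenyl gives a 1.4-fold higher number from compound 1 to compound 3 (0.15 log units; within the scatter), so this position tolerates amino, with its hydrogen-bond donor and acceptor, as well as methyl. The swap from 4-(trifluoromethyl)phenyl to 3-aminophenyl gives a 3.1-fold lower number from compound 2 to compound 3 (0.50 log units; beyond the scatter) and changes both the group and its place, so it cannot show which of the two matters. Nothing measured here offers a reason for these numbers. Still open, from the compounds shown here alone, is how a carboxylic acid or a methoxy group would fare at this position. Also open, going by these compounds, is how amino would fare elsewhere on the same ring.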